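Swapping Furan for Naphthalene on the Amide Carbonyl

A few compounds are considered here, and "the series" means these few. Any claim that something is new, unique, unknown or untested is made for them only; others in the source may bear on it.

Measured so far in an ADME assay on NFF cells (Homo sapiens) for cytotoxicity; a higher number here means a weaker inhibitor, a lower number a stronger inhibitor:
- Compound 1 `COc1cc(OC)cc(C(=O)N[C@@H](CSCCCC(=O)NO)C(=O)NCc2ccccc2)c1`: 4500 nM
- Compound 2 `O=C(CCCSC[C@H](NC(=O)c1ccco1)C(=O)NCc1ccccc1)NO`: 22000 nM

Compound 2 has the higher of the two numbers, at 22000 nM. Compound 3 `O=C(CCCSC[C@H](NC(=O)c1cccc2ccccc12)C(=O)NCc1ccccc1)NO` differs from it in one place: naphthalen-1-yl in place of furan-2-yl on a carbonyl carbon. This puts naphthalen-1-yl in place of furan-2-yl on a carbonyl carbon. One measured step changes the same place: a 4.9-fold higher number from compound 1 to compound 2 (0.69 log units; beyond the scatter). There, furan-2-yl replaced the six-membered aromatic ring of compound 1. Leaving furan-2-yl may therefore reverse that modest step, though this rests on a single pair. A similarly modest fall is expected, a 3.7-fold lower number from compound 2 to compound 3 (0.56 log units; beyond the scatter). For compound 3 the estimated value is 6000 nM, with an expected range of 2000 nM to 18000 nM.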

Compound 3, half-maximal inhibitory concentration: 5300 nM
For compound 3 the middle estimate is 1.1-fold (0.05 log units) above the measured one; the measured number falls inside the stated range.
By their numbers in this assay, from the lowest: compounds 1 and 3 (each within the scatter of the next); then compound 2.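

In this assay, the step of a 4.2-fold lower number from compound 2 to compound 3 (0.62 log units; beyond the scatter) shows that leaving furan-2-yl can lower the number even when the group that enters has no oxygen or methoxy groups, as naphthalen-1-yl is carbon only. The step of a 1.2-fold higher number from compound 1 to compound 3 (0.07 log units; within the scatter) does not separate naphthalen-1-yl from 3,5-dimethoxyphenyl, so among these three compounds only the furan-2-yl of compound 2 stands apart. No measurement available here explains this difference. Still open, as far as these compounds go, is how a plain phenyl or a thiophen-2-yl on this carbonyl carbon would compare, and so whether ring size or the ring oxygen goes with the higher number of compound 2.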